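Bis-arylidene piperidinones with triazolylmethyl arms: cytotoxicity notes

The compounds below may be only part of what the source reports. "The series", "measured", "known", "first", "only" and "open" are said of these compounds alone.

Measured so far:
compound 1 `COc1ccc(/C=C2\CN(C(=S)SCc3cn(Cc4ccccc4Cl)nn3)C/C(=C\c3ccc(OC)cc3)C2=O)cc1` — > 80000 nM
compound 2 `O=C1/C(=C/c2ccccc2F)CN(C(=S)SCc2cn(Cc3cccc(Cl)c3)nn2)C/C1=C\c1ccccc1F` — > 80000 nM
compound 3 `Cc1ccc(/C=C2\CN(Cc3cn(Cc4cccc(Cl)c4)nn3)C/C(=C\c3ccc(C)cc3)C2=O)cc1` — 33100 nM

In a functional assay on DU-145 cells (Homo sapiens) for cytotoxicity, read by MTT assay, with a stated time of 24 h (on this read-out lower numbers stand for stronger inhibition and higher numbers for weaker inhibition), compound 1 returns only a limit, > 80000 nM. In this assay compound 2 likewise returns only a limit, > 80000 nM. For the measured compounds named here, compound 3 is the only member with a number, 33100 nM; the other two sit at the limit of > 80000 nM in this assay, at which 2 of the 3 values shown sit. Compound 4 `Cc1ccc(/C=C2\CN(Cc3cn(Cc4ccccc4F)nn3)C/C(=C\c3ccc(C)cc3)C2=O)cc1` differs from compound 3 by 2-fluorophenyl in place of 3-chlorophenyl on a saturated chain carbon bound to an aromatic nitrogen. Going by the values given here, no measured pair separates this change from other differences, so no step is known for it. The expectation is that the change from compound 3 to compound 4, a 1.4-fold higher number from compound 3 to compound 4 (0.13 log units; within the scatter), stays within the scatter of this assay, with a real risk that only a limit is reported. Compound 4 is estimated at 45000 nM, between 15000 nM and 150000 nM.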

Compound 4, half-maximal inhibitory concentration: 9500 nM
Compound 4: middle estimate off by 4.7-fold (0.68 log units), on the high side, outside the stated range (below it).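

In this assay, the group on a saturated chain carbon bound to an aromatic nitrogen proves able to shift the read-out: 2-fluorophenyl in place of 3-chlorophenyl gives a 3.5-fold lower number from compound 3 to compound 4 (0.54 log units; beyond the scatter), a modest step and the first readable one in the series. Nothing shown gives a measured basis for this step.

The change alters both the halogen and its ring position, so the two effects remain unseparated; a 3-fluorobenzyl group on the same scaffold would divide them. As far as these compounds go, whether an unsubstituted benzyl or an aminomethyl-bearing benzyl keeps the gain also remains open.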